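A few compounds are considered here, and "the series" means these few. Any claim that something is new, unique, unknown or untested is made for them only; others in the source may bear on it.

Measured in an assay on cell membranes for displacement of a labelled ligand from Sigma non-opioid intracellular receptor 1 (Rattus norvegicus); a higher number here means a weaker inhibitor, a lower number a stronger inhibitor: compound 1 `O=c1sc2ccccc2n1CCCCN1CCCCCC1` gives 3.2 nM; compound 2 `CCCC(=O)c1ccc2c(c1)sc(=O)n2CCCN1CCCCCC1` gives 2.6 nM.

Compound 2 has the lower of the two numbers, but compound 1 sits only slightly higher, and the two values are within the scatter of each other. Compound 1 and compound 2 also differ from each other in more than one place, so no single change between them can be read from these numbers.

Compound 3 `CCCC(=O)c1ccc2c(c1)sc(=O)n2CCCCN1CCCCCC1` is not yet measured. It differs from compound 2 in one place: (azepan-1-yl)methyl in place of azepan-1-yl on a saturated chain carbon, three bonds along the chain from an aromatic nitrogen. For the measured compounds named here, no such single step between measured compounds is available in this assay. Given that compound 1 and compound 2 already give values within the scatter of each other, no step beyond the scatter is expected here in either direction. The step from compound 2 to compound 3 is therefore estimated as a 1.0-fold lower number from compound 2 to compound 3 (0.02 log units; within the scatter). Compound 3 is expected to give about 2.5 nM, in the range 1 nM to 7 nM.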

Compound 3, inhibition constant: 4.8 nM
For compound 3 the middle estimate is 1.9-fold (0.28 log units) below the measured one; the range from low to high includes it.
By their numbers in this assay, from the lowest: compounds 2, 1 and 3 (each within the scatter of the next).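

In this assay the series now has its first steps that differ in one place. Putting (azepan-1-yl)methyl in place of azepan-1-yl on a saturated chain carbon, three bonds along the chain from an aromatic nitrogen, gives (a 1.8-fold higher number from compound 2 to compound 3 (0.27 log units; within the scatter)), and putting propylcarbonyl in place of hydrogen on an aromatic carbon gives (a 1.5-fold higher number from compound 1 to compound 3 (0.18 log units; within the scatter)). Neither change therefore moves the number beyond the scatter in these compounds, and nothing measured here bears on why.

Going by these compounds, it remains open whether a longer chain carrying the azepane would stay within the scatter of compound 3, or whether a piperidine or a dimethylamine in place of the azepane would do so. Also open, on these data alone, is how an acetyl group or a carboxylic acid in place of propylcarbonyl would read in this assay.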